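A few compounds are considered here, and "the series" means these few. Any claim that something is new, unique, unknown or untested is made for them only; others in the source may bear on it.

Compound 1 `CCCCOC(=O)C1=CCCCC1S(=O)(=O)Cc1ccc(F)cc1Cl`: 103 nM
Compound 2 `CCCC(=O)C1=CCCCC1S(=O)(=O)Cc1ccc(F)cc1Cl`: 11 nM

In a functional assay on RAW264.7 cells (Mus musculus), read by fluorescence (on this read-out lower numbers stand for stronger inhibition and higher numbers for weaker inhibition), compound 1 gives 103 nM. Within the data shown here, compound 2 gives 11 nM in this assay, the lowest of the two numbers measured so far; its only neighbour is compound 1, and the distance between them is the step of a 9.4-fold lower number from compound 1 to compound 2 (0.97 log units; beyond the scatter), an exchange of butoxy for propyl on the carbonyl carbon. That single step is the whole measured record.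

Compound 3 `CCC(O)C1=CCCCC1S(=O)(=O)Cc1ccc(F)cc1Cl` has not yet been measured. It differs from compound 2 by 1-hydroxypropyl in place of propylcarbonyl on a double-bonded ring carbon. The carbonyl that was kept through the first step is now gone, and a hydrogen-bond donor appears where there was none. Among the measured compounds shown here, no measured step covers a change of this kind: the step between compound 1 and compound 2 touches only the group attached to the carbonyl, not the carbonyl itself, so it offers no direct guide. Compound 2 is the closer relative and therefore the anchor. Because compound 2 stands at 11 nM, compound 3 is expected to land somewhat higher, estimated at 40 nM, with a range from 10 nM to 200 nM. The step this estimate implies, a 3.6-fold higher number from compound 2 to compound 3 (0.56 log units; beyond the scatter), is an expectation only.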

Compound 3, half-maximal inhibitory concentration: > 10000 nM
Compound 3: only a limit was reported; the forecaster's own chance of this, stated with the estimate: 5%; at least 250-fold (2.39 log units) between middle value and limit.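

In this assay compound 3 is reported only as a limit, not as a number: the limit of > 10000 nM in this assay, at which 1 of the 3 values shown sits. On the double-bonded ring carbon, 1-hydroxypropyl gives an at least 900-fold higher number from compound 2 to compound 3 (2.95 log units; beyond the scatter), and measured against the butoxycarbonyl group it gives an at least 97-fold higher number from compound 1 to compound 3 (1.98 log units; beyond the scatter), so both steps are far larger than the earlier change on the far side of the carbonyl, a 9.4-fold lower number from compound 1 to compound 2 (0.97 log units; beyond the scatter). Among these compounds, the earlier pair showed only that the group attached to the carbonyl shifts the number, whereas this result shows that inhibition in these compounds can almost vanish when the carbonyl itself gives way to a carbon bearing a hydroxyl, so this position is far less forgiving than the first step suggested.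

Two things change at once in this step, the carbonyl leaves and a hydrogen-bond donor enters, and the compounds shown cannot tell which of the two matters. As far as these compounds go, a plain butyl chain, a methyl ether or an amide on this ring carbon would pull those two changes apart, and whether any of them keeps the inhibition seen with the carbonyl compounds remains open.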